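Adding a methoxy group to a pyrazoline sulfonamide series

A few compounds are considered here, and "the series" means these few. Any claim that something is new, unique, unknown or untested is made for them only; others in the source may bear on it.

Three pyrazoline sulfonamides were tested in a functional assay on the whole organism (strain Wistar) for inhibition, with Rattus norvegicus as the target, read by paw edema, with stated times of 30 min and 3 h, at a dose of 20 mg/kg by the oral route; a higher number here means more inhibition at the dose given (going by the name of the read-out), a lower number less inhibition. Compound 1 `COc1ccc(C2CC(c3cc(Cl)c(C)cc3O)=NN2c2ccc(S(N)(=O)=O)cc2)cc1OC` gives 60.5% in this assay. Compound 2 `COc1ccc(C2CC(c3cc(Cl)c(C)cc3O)=NN2c2ccc(S(N)(=O)=O)cc2)c(OC)c1OC` differs from compound 1 by methoxy in place of hydrogen on an aromatic carbon and in this assay compound 2 gives 68.4%; the step of a number 7.9 percentage points higher from compound 1 to compound 2 (within the scatter) lies within the scatter, so the two numbers cannot be ordered. Compound 3 `COc1ccc(C2CC(c3cc(Cl)c(C)cc3OC)=NN2c2ccc(S(N)(=O)=O)cc2)cc1OC` differs from compound 1 by methyl in place of hydrogen on an oxygen on an aromatic ring, and in this assay compound 3 gives 31.6%, the lowest of the three; the step of a number 28.9 percentage points lower from compound 1 to compound 3 (beyond the scatter) lies beyond the scatter, as does the gap between compound 3 and compound 2.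

Compound 4 `COc1cc(C)c(Cl)cc1C1=NN(c2ccc(S(N)(=O)=O)cc2)C(c2ccc(OC)c(OC)c2OC)C1` has not yet been measured. It is related to compound 3 in the same way as compound 2 is related to compound 1: the difference is methoxy in place of hydrogen on an aromatic carbon, and the place of the change is described in the same words for both pairs, so this is the same change on a different core. The two cores differ by methyl in place of hydrogen on an oxygen on an aromatic ring. Among the compounds with values here, the only guide to the size of the coming step is the earlier one, which stayed within the scatter. On that basis compound 4 is expected to show a step of a number 6.4 percentage points higher from compound 3 to compound 4 (within the scatter) in this assay, a step that would again be within the scatter. The estimate for compound 4 in this assay is therefore 38%, with a range from 24% to 52%, resting on one earlier step from one pair, which is a thin basis.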

Compound 4, a percentage reported as inhibition, in the whole organism at one dose (the size of the read-out at that dose, not a potency): 34.2%
For compound 4 the middle estimate is 3.8 percentage points above the measured one; the measured number falls inside the stated range.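

In this assay, methoxy in place of hydrogen on an aromatic carbon, here 3,4-dimethoxyphenyl to 2,3,4-trimethoxyphenyl, gives a number 2.6 percentage points higher from compound 3 to compound 4 (within the scatter), so on neither core can this change be told from the scatter, and the two steps agree: the same change on two cores in this assay, a number 7.9 percentage points higher (within the scatter) from compound 1 to compound 2 and a number 2.6 percentage points higher (within the scatter) from compound 3 to compound 4, 5.3 percentage points apart, within the scatter of two such steps

Methyl in place of hydrogen on an oxygen on an aromatic ring gives a number 34.2 percentage points lower from compound 2 to compound 4 (beyond the scatter), so this loss of inhibition is seen with both the 3,4-dimethoxyphenyl and the 2,3,4-trimethoxyphenyl groups, and its size carries over: the same change on two cores in this assay, a number 28.9 percentage points lower (beyond the scatter) from compound 1 to compound 3 and a number 34.2 percentage points lower (beyond the scatter) from compound 2 to compound 4, 5.3 percentage points apart, within the scatter of two such steps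

Within the data shown here, this agreement rests on only two pairs of compounds, read at one dose and as a size of effect rather than a potency, so it does not show that either change would carry over to any other core, and it gives no reason for what is seen.

The compounds shown leave open whether a longer chain, such as ethoxy, on the same oxygen would give a step like that of methyl. They also leave open whether an amine or a carboxylic acid in place of the added methoxy would give a step beyond the scatter.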